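Trifluoromethyl to Fluoro Across Two Related Cores

The source may report more compounds than this note shows. Statements on the series, on what has been measured and on what is new or still open speak of the compounds shown alone.

Compound 1 `C=C1C[C@]23C[C@@]1(O)CC[C@H]2c1ccc(O)c(C)c1[C@@H]3Cn1cc(-c2ccc(C(F)(F)F)cc2)nn1` was tested in a functional assay on SW480 cells (Homo sapiens) for cytotoxicity, read by MTT assay, with a stated time of 4 days; on this read-out higher numbers stand for weaker inhibition and lower numbers for stronger inhibition. In this assay compound 1 gives > 20000 nM, which is a limit of the assay rather than a number. Compound 2 `C=C1C[C@]23C[C@@]1(O)CC[C@H]2c1ccc(O)c(C)c1[C@@H]3Cn1cc(-c2ccc(F)cc2)nn1` carries the change (fluoro in place of trifluoromethyl on an aromatic carbon). In this assay compound 2 gives > 20000 nM, again a limit. The step that the two limits leave unreadable from compound 1 to compound 2 therefore cannot be sized. Compound 3 `Cc1ccc(S(=O)(=O)Oc2ccc3c(c2C)[C@H](Cn2cc(-c4ccc(C(F)(F)F)cc4)nn2)[C@@]24CC(=O)[C@@](C)(CC[C@@H]32)C4)cc1` rests on a different core; the difference between the two cores is not broken down here. In this assay compound 3 gives > 20000 nM, also a limit. Every value shown sits at the limit of > 20000 nM in this assay, at which 3 of the 3 values shown sit. Compound 4 `Cc1ccc(S(=O)(=O)Oc2ccc3c(c2C)[C@H](Cn2cc(-c4ccc(F)cc4)nn2)[C@@]24CC(=O)[C@@](C)(CC[C@@H]32)C4)cc1` arises from compound 3 by the same change, (fluoro in place of trifluoromethyl on an aromatic carbon). Because every measured value rests at the limit of > 20000 nM in this assay, at which 3 of the 3 values shown sit, the expected step is a step that the limit leaves unreadable from compound 3 to compound 4. Compound 4 is expected to give about 30000 nM, most likely reported again only as a limit.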

Compound 4, half-maximal inhibitory concentration: > 20000 nM
Compound 4 gave a limit, no number; the forecaster's own chance of this, stated with the estimate: 85%; the middle value does not contradict the limit.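

Compound 3 and compound 4 each give only a limit, not a number, so no step can be read between them: the limit of > 20000 nM in this assay, at which 4 of the 4 values shown sit. The compounds shown leave open whether swapping trifluoromethyl for fluoro changes anything where a compound gives a real number.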